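Reworking the aryl group in a prostacyclin synthase inhibitor series

The compounds below may be only part of what the source reports. "The series", "measured", "known", "first", "only" and "open" are said of these compounds alone.

This series shares a core carrying a pyridyl ring and a carboxylic acid chain, varying only in the group on the saturated chain carbon. Compound 1, `N#Cc1ccccc1C1OCC(C/C=C\CCC(=O)O)C(c2cccnc2)O1`, is measured in an assay for inhibition of prostacyclin synthase (Homo sapiens), using microsomes; on this read-out higher numbers stand for weaker inhibition and lower numbers for stronger inhibition. In this assay compound 1 gives > 100000 nM, which is a limit of the assay and not a number (the limit of > 100000 nM in this assay, at which 1 of the 3 values shown sits). Compound 2, `CC(C)(Oc1ccc(F)cc1)C1OCC(C/C=C\CCC(=O)O)C(c2cccnc2)O1`, gives 2000 nM in this assay. Among the compounds with values here, compound 3, `Cc1ccc(OC(C)(C)C2OCC(C/C=C\CCC(=O)O)C(c3cccnc3)O2)cc1`, gives 25000 nM in this assay, the highest of the two numbers available, and the one step that reaches it is a 13-fold higher number from compound 2 to compound 3 (1.10 log units; beyond the scatter).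

Compound 4, `CC(C)(Cc1ccc(F)cc1C#N)C1OCC(C/C=C\CCC(=O)O)C(c2cccnc2)O1`, is not yet measured. Relative to compound 3 it carries a group of 10 heavy atoms (8 carbon, 1 nitrogen, 1 fluorine; one six-membered aromatic ring of carbon only) in place of a group of 8 heavy atoms (7 carbon, 1 oxygen; one six-membered aromatic ring of carbon only), on a saturated chain carbon bound to two saturated chain carbons and a saturated ring carbon. Within the data shown here, no measured step covers this exact change. Among the measured compounds shown here, the only step with a number on both sides, a 13-fold higher number from compound 2 to compound 3 (1.10 log units; beyond the scatter), shows that swapping a methyl for a fluoro moves this assay by a large amount, and compound 4 restores a fluoro on the aromatic ring while also adding a nitrile and replacing the oxygen link with a carbon. The author therefore expects a number between those of compound 2 and compound 3, with a wide range; the estimated step is a 4.2-fold lower number from compound 3 to compound 4 (0.62 log units; beyond the scatter). The estimate for compound 4 in this assay is 6000 nM, expected to fall between 800 nM and 50000 nM.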

Compound 4, half-maximal inhibitory concentration: 7000 nM
Estimate against measurement, compound 4: 1.2-fold (0.07 log units) below; measured number inside the range.
By their numbers in this assay, from the lowest: compound 2; then compound 4; then compound 3. At a limit, above all of these: compound 1.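

In this assay, the group on the saturated chain carbon bound to two saturated chain carbons and a saturated ring carbon proves open to a change that brings in a nitrile and a fluorine and removes the oxygen: there is a 3.6-fold lower number from compound 3 to compound 4 (0.55 log units; beyond the scatter), and also a 3.5-fold higher number from compound 2 to compound 4 (0.54 log units; beyond the scatter). Both steps lie beyond the scatter, so the new group places compound 4 in the interval marked out by compound 2 and compound 3, without matching either. Among these three compounds, then, an oxygen in this group is not needed for a measurable number, though the compound with the lowest number, compound 2, does carry one, and nothing shown here accounts for the size of either step.

Compound 4 differs from compound 2 and compound 3 in its oxygen, its nitrile and its ring substituents all at once, so the share of each in these steps remains unresolved. Also open, going by these compounds, is how this position would respond to a group carrying an amine or an amide in place of the nitrile.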